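This account rests on a few compounds, and the source may have more. Where it says the series, first, only, none or still open, it means among the compounds named here.

Values from a functional assay on MDA-MB-468 cells (Homo sapiens) for antiproliferative activity (on this read-out higher numbers stand for weaker inhibition of growth and lower numbers for stronger inhibition of growth), follow.
- Compound 1 (`Cc1cc(-c2nc3ccccc3s2)ccc1N`) gives < 0.1 nM as a limit of the assay, not a number.
- Compound 2 (`COc1ccc(-c2nc3cc(F)ccc3s2)cc1Cl`) gives 480 nM as a measured number.
- Compound 3 (`COc1ccc(-c2nc3cc(F)ccc3s2)c(OC)c1OC`) gives 120 nM as a measured number.

Of the two true numbers, compound 2 at 480 nM has the higher, and the gap to compound 3 lies beyond the scatter. Compound 4 (`CCOc1cc(-c2nc3cc(F)ccc3s2)ccc1OC`) has ethoxy in place of chloro on an aromatic carbon, ortho to a methoxy group (ethoxy in place of chloro on an aromatic carbon). Going by the values given here, no measured step covers this change. The expectation rests on compound 3 at 120 nM as a compound with methoxy groups and no chloro. The expected change is a 40-fold lower number from compound 2 to compound 4 (1.60 log units; beyond the scatter) towards stronger inhibition of growth, beyond the scatter. For compound 4 the estimate is 12 nM with an expected range from 0.5 nM to 200 nM in this assay.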

Compound 4, concentration for 50% growth inhibition: 92 nM
Compound 4: the middle estimate sits 7.7-fold (0.88 log units) below what was measured; the range from low to high includes it.
By their numbers in this assay, from the lowest: compounds 4 and 3 (each within the scatter of the next); then compound 2. At a limit, below all of these: compound 1.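

Going by these compounds alone, on an aromatic carbon ortho to a methoxy group, ethoxy in place of chloro gives a 5.2-fold lower number from compound 2 to compound 4 (0.72 log units; beyond the scatter) in this assay, the only single-place step available so far. This position therefore accepts ethoxy, with 3 heavy atoms and 1 hydrogen-bond acceptor, in place of chloro without loss of growth inhibition. No available measurement bears on the reason for this step. The compounds shown leave open how a methoxy group, a propoxy group or an amine would compare at this position.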